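The compounds below may be only part of what the source reports. "The series", "measured", "known", "first", "only" and "open" are said of these compounds alone.

Measured compounds:
- compound 1, `O=C(NCCCCc1ccccc1)c1cccc(C2SCC(=O)N2c2cnccn2)c1`: > 1000 nM in a functional assay on HOS-TE85 cells (Homo sapiens) for inhibition, read by CCK-8 assay, with a stated time of 72 h; on this read-out higher numbers stand for weaker inhibition and lower numbers for stronger inhibition
- compound 2, `C#Cc1cc(C(=O)NCCCCc2ccccc2)cc(C2SCC(=O)N2c2ccccc2OC)c1`: 40.8 nM
- compound 3, `O=C(NCCCCn1cccn1)c1cccc(C2SCC(=O)N2c2ccncc2)c1`: > 1000 nM

Compound 1 gives only a limit of the assay in this assay, so its inhibition is weaker than the assay can resolve. Compound 3 likewise gives only a limit, and the limit of > 1000 nM in this assay, at which 2 of the 3 values shown sit, records that two of the three values shown stop there. Compound 2, which carries a carbon-only aromatic ring with a methoxy group on the amide-type nitrogen of the shared core and an ethynyl on the benzamide ring, gives a number within the measured range. Compound 4, `O=C(NCCCCc1ccccc1)c1cccc(C2SCC(=O)N2c2ccc(C3CC3)cc2)c1`, has not yet been measured. It differs from compound 1 in one place: 4-cyclopropylphenyl in place of pyrazin-2-yl on an amide-type nitrogen in a ring. For the measured compounds named here, no measured pair shows this exact change, so no step between measured compounds can be quoted. Given that compound 2, the only compound here with a carbon-only aromatic ring on that nitrogen, gives 40.8 nM, compound 4 is expected to move toward stronger inhibition, with the step of an at least 4.0-fold lower number from compound 1 to compound 4 (0.60 log units; beyond the scatter) expected to reach beyond the scatter. The estimate for compound 4 is 250 nM, between 40 nM and 1500 nM, with a real chance that only a limit is again reported.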

Compound 4, half-maximal inhibitory concentration: 217 nM
For compound 4 the middle estimate is 1.2-fold (0.06 log units) above the measured one; low and high end bracket the measured number.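

In this assay compound 1 gives > 1000 nM, which is a limit of the assay and not a number. Putting 4-cyclopropylphenyl in place of pyrazin-2-yl on the amide-type nitrogen in the ring produces an at least 4.6-fold lower number from compound 1 to compound 4 (0.66 log units; beyond the scatter), so this position can turn a compound that stops at the limit into one with a measurable value when nothing else in the structure changes. The full size of this step cannot be read, since compound 1 stands at a limit: the limit of > 1000 nM in this assay, at which 2 of the 4 values shown sit.

The compounds shown leave open whether the phenyl ring alone is enough, which a plain phenyl group at this position would test. They also leave open how an amine or a carboxylic acid in place of the cyclopropyl group on that ring would affect the value.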